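A few compounds are considered here, and "the series" means these few. Any claim that something is new, unique, unknown or untested is made for them only; others in the source may bear on it.

Among the compounds with values here, in a functional assay on G-361 cells (Homo sapiens) for inhibition, with a stated time of 72 h (on this read-out lower numbers stand for stronger inhibition and higher numbers for weaker inhibition), compound 1 (`NC1CCC(Nc2nc(NCc3ccc(-c4cccc(F)c4)cc3)c3ncn(C4CCCC4)c3n2)CC1`) gives 815 nM as the higher of the two numbers so far, while compound 2 (`NC1CCC(Nc2nc(NCc3ccc(-c4cccc(F)c4)nc3)c3ncn(C4CCCC4)c3n2)CC1`) gives 49 nM and lies lower by more than the usual scatter. Compound 3 (`NC1CCC(Nc2nc(NCc3ccc(-c4ccccc4O)cc3)c3ncn(C4CCCC4)c3n2)CC1`) differs from compound 1 by 2-hydroxyphenyl in place of 3-fluorophenyl on an aromatic carbon. Within the data shown here, no measured pair shows this change, so in this assay only a modest step toward a lower number is expected, possibly none beyond the scatter. The estimated step of a 2.0-fold lower number from compound 1 to compound 3 (0.31 log units; beyond the scatter) is thus small. Compound 3 is expected at 400 nM with an estimated range from 120 nM to 1300 nM in this read-out.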

Compound 3, half-maximal inhibitory concentration: 4150 nM
The estimate for compound 3 lay 10-fold (1.02 log units) below the measured number; the whole stated range lies below it.
By their numbers in this assay, from the lowest: compound 2; then compound 1; then compound 3.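

In this assay, putting 2-hydroxyphenyl in place of 3-fluorophenyl gives a 5.1-fold higher number from compound 1 to compound 3 (0.71 log units; beyond the scatter), a modest step toward weaker inhibition. This shows that the read-out responds to the group at this position, and that this swap, which brings in a hydrogen-bond donor and acceptor, does not strengthen inhibition. No evidence at hand explains the change. Because the group's substituent and its place on the ring change together, these compounds cannot separate the two. As far as these compounds go, how 3-hydroxyphenyl, 2-fluorophenyl or 3-aminophenyl would compare remains open.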